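Tetrazolyl pyridine carboxamides: bromo to phenoxy step

The source may report more compounds than this note shows. Statements on the series, on what has been measured and on what is new or still open speak of the compounds shown alone.

Measured compounds in a functional assay on the whole organism for inhibition, with Rattus norvegicus as the target, at a dose of 10 mg/kg by the oral route; on this read-out lower numbers stand for a weaker effect and higher numbers for a stronger effect at the one dose given:
- compound 1, `O=C(Nc1nn[nH]n1)c1cccc(Br)n1`, gives 48%
- compound 2, `COc1cccnc1C(=O)Nc1nn[nH]n1`, gives 0%
- compound 3, `Cc1cccnc1C(=O)Nc1nn[nH]n1`, gives 69%

On these three numbers compound 1 stands second highest. Its nearest neighbour is compound 3, and the gap between them lies beyond the scatter, with compound 3 the stronger. Compound 2 is furthest away, with the weakest read-out of the set, again beyond the scatter.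

Among the compounds with values here, the only single-point step among the measured compounds is a number 69 percentage points higher from compound 2 to compound 3 (beyond the scatter). It concerns a methyl in place of methoxy on the shared core and does not touch the position changed here.

Compound 4, `O=C(Nc1nn[nH]n1)c1cccc(Oc2ccccc2)n1`, differs from compound 1 as follows: phenoxy in place of bromo on an aromatic carbon. Within the data shown here, no measured step bears on this change, so the direction cannot be read from the set. The one oxygen-linked substituent measured, the methoxy of compound 2 at another position, gives the lowest number of the set, which argues for caution rather than for a rise.

For compound 4 the estimate in this assay is 35%, with a range from 5% to 70%. This estimate amounts to an expected step of a number 13 percentage points lower from compound 1 to compound 4 (beyond the scatter).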

Compound 4, a percentage reported as inhibition, in the whole organism at one dose (the size of the read-out at that dose, not a potency): 0%
Compound 4: middle estimate off by 35 percentage points, on the high side; the whole stated range lies above it.
By their numbers in this assay, from the lowest: compounds 2 and 4 (each within the scatter of the next); then compound 1; then compound 3.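

In this assay this position proves sensitive to the size of the change, with a number 48 percentage points lower from compound 1 to compound 4 (beyond the scatter) on going from bromo to phenoxy. Within the data shown here, the earlier compounds could not show this, since their single measured step, methyl in place of methoxy, lies elsewhere on the shared core and says nothing about the aromatic carbon next to the ring nitrogen. No measured property accounts for the drop, and the pair alone does not separate the oxygen link from the added six-membered aromatic ring or from the rise from 1 heavy atom to 7 heavy atoms.

Still open, as far as these compounds go, is whether a smaller group at this position, such as methoxy, methyl or chloro, would keep the read-out of compound 1, and whether an amine or a benzyl group, with no oxygen link, would behave like phenoxy. A read-out at one oral dose in the whole organism also leaves open how far the weaker effect at that dose reflects action at the target rather than exposure.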